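The compounds below may be only part of what the source reports. "The series", "measured", "known", "first", "only" and "open" are said of these compounds alone.

Working notes on the series. Two compounds carry numbers in an assay on cells for agonist activity at vitamin D3 receptor (Homo sapiens), read by microscopy; a lower number here means that less compound is needed, a higher number that more compound is needed for the effect. Compound 1 `CCn1c(C(=O)NCCCO)ccc1C(CC)(CC)c1ccc(C#CC(O)(CC)CC)c(C)c1` gives 137 nM in this assay. Compound 2 `CCN(CC)CCNC(=O)c1cc(C(CC)(CC)c2ccc(C#CC(O)(CC)CC)c(C)c2)cn1CC` gives 6.98 nM in this assay, the lowest of the two numbers; the step from compound 2 up to compound 1 lies beyond the scatter. Within the data shown here, no pair differing in one place has been measured, so no single step is known.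

Compound 3 `CCn1cc(C(CC)(CC)c2ccc(C#CC(O)(CC)CC)c(C)c2)cc1C(=O)OCCO` has not yet been measured in this assay. It differs from compound 2 by 2-hydroxyethoxy in place of (2-(diethylamino)ethyl)amino on a carbonyl carbon.

For compound 3 a step upward from compound 2, beyond the scatter, is expected, an 8.6-fold higher number from compound 2 to compound 3 (0.93 log units; beyond the scatter), the only hydroxyl-bearing chain measured so far being that of compound 1, which gives 137 nM in this assay. Compound 3 is estimated at 60 nM in this assay, with a range from 15 nM to 300 nM.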

Compound 3, half-maximal effective concentration: 12.6 nM
For compound 3 the middle estimate is 4.8-fold (0.68 log units) above the measured one; the whole stated range lies above it.
By their numbers in this assay, from the lowest: compounds 2 and 3 (each within the scatter of the next); then compound 1.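

Working from the carbonyl carbon, the series now has its first single change that can be read: a 1.8-fold higher number from compound 2 to compound 3 (0.26 log units; within the scatter) in this assay, a step that stays within the scatter. This position therefore accepts 2-hydroxyethoxy, with 4 heavy atoms including 2 oxygen, in place of (2-(diethylamino)ethyl)amino, with 8 heavy atoms including 2 nitrogen, without a step beyond the scatter, and the diethylamino end of the chain is not needed to stay within it. No measurement at hand bears on why the two chains read alike.

Still open, from the compounds shown here alone, is whether a carboxylic acid, a primary amine or a longer chain on this carbonyl carbon would also stay within the scatter of compound 2. Also open, going by these compounds, is whether the same exchange reads alike on the core of compound 1, which differs from compound 2 in more than one place.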